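Swapping tert-butyl for hydrogen on a weak benzothiazole analogue

The compounds below may be only part of what the source reports. "The series", "measured", "known", "first", "only" and "open" are said of these compounds alone.

Measured compounds and their values:
Compound 1, `CC(C)(C)Oc1ccc(-c2nnc(SCCCN3CCN(c4nc5ccccc5o4)CC3)o2)cc1`: 263000 nM
Compound 2, `Oc1ccc(-c2nnc(SCCCN3CCN(c4nc5ccccc5o4)CC3)o2)cc1`: 181000 nM
Compound 3, `CC(C)(C)Oc1ccc(-c2nnc(SCCCN3CCN(c4nc5ccccc5s4)CC3)o2)cc1`: 71600 nM

All three compounds were tested in a functional assay on A549 cells (Homo sapiens) for inhibition, read by MTT assay, with a stated time of 72 h; a lower number here means a stronger inhibitor, a higher number a weaker inhibitor. In this assay compound 1 gives 263000 nM, compound 2 gives 181000 nM and compound 3 gives 71600 nM. Among the three, compound 3 has the lowest number, and its steps to both others are beyond the scatter.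

Two changes connect them. From compound 1 to compound 2 the change is hydrogen in place of tert-butyl on an oxygen on an aromatic ring. This made a 1.5-fold lower number from compound 1 to compound 2 (0.16 log units; within the scatter). From compound 1 to compound 3 the change is 1,3-benzothiazol-2-yl in place of 1,3-benzoxazol-2-yl on an amine nitrogen in a ring, which made a 3.7-fold lower number from compound 1 to compound 3 (0.57 log units; beyond the scatter).

Compound 4, `Oc1ccc(-c2nnc(SCCCN3CCN(c4nc5ccccc5s4)CC3)o2)cc1`, has not yet been measured. It differs from compound 3 by hydrogen in place of tert-butyl on an oxygen on an aromatic ring. This is the same change as that from compound 1 to compound 2, since the place is described in the same words in both cases; the two cores differ by 1,3-benzothiazol-2-yl in place of 1,3-benzoxazol-2-yl on an amine nitrogen in a ring.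

Among the measured compounds shown here, the one earlier instance of this change gave a 1.5-fold lower number from compound 1 to compound 2 (0.16 log units; within the scatter), a step within the scatter. On a single example, the step from compound 3 to compound 4 is expected to be about as small, a 1.4-fold lower number from compound 3 to compound 4 (0.16 log units; within the scatter), and compound 4 is therefore estimated at 50000 nM, with a plausible range from 20000 nM to 150000 nM.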

Compound 4, half-maximal inhibitory concentration: 62100 nM
Beside the measured number, compound 4's estimate is 1.2-fold (0.09 log units) below it; the range from low to high includes it.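

In this assay, putting hydrogen in place of tert-butyl on the oxygen gave a 1.2-fold lower number from compound 3 to compound 4 (0.06 log units; within the scatter), so this change again left the number within the usual scatter, and it behaved alike on both cores: the same change on two cores in this assay, a 1.5-fold lower number (0.16 log units; within the scatter) from compound 1 to compound 2 and a 1.2-fold lower number (0.06 log units; within the scatter) from compound 3 to compound 4, 1.3-fold (0.10 log units) apart, within the scatter of two such steps

The second change also carried over, as 1,3-benzothiazol-2-yl in place of 1,3-benzoxazol-2-yl gave a 2.9-fold lower number from compound 2 to compound 4 (0.46 log units; beyond the scatter), again in agreement with its earlier step: the same change on two cores in this assay, a 3.7-fold lower number (0.57 log units; beyond the scatter) from compound 1 to compound 3 and a 2.9-fold lower number (0.46 log units; beyond the scatter) from compound 2 to compound 4, 1.3-fold (0.10 log units) apart, within the scatter of two such steps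

Together, these four compounds show that each of the two changes had a similar effect on the two cores tested here, but two examples of each change in one assay do not make a general rule for the series, and they do not show that either step would keep its size on a core with a further change.

The compounds shown leave open whether anything other than hydroxy or tert-butoxy at this place, such as an amine, a carboxylic acid or a longer chain, would move the number beyond the scatter. They also leave open whether the two steps would keep their size in any other assay.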